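Swapping methoxy for acetamido on the benzyl arm

This account rests on a few compounds, and the source may have more. Where it says the series, first, only, none or still open, it means among the compounds named here.

Three compounds share one core and differ only in the group carried on an aromatic nitrogen. Compound 1, `COc1ccc(-n2nc(Nc3cc(C)[nH]n3)c3ccccc3c2=O)cc1`, carries a 4-methoxyphenyl there; in a functional assay on COLO 205 cells (Homo sapiens) for cytotoxicity (a higher number here means a weaker inhibitor, a lower number a stronger inhibitor), compound 1 gives 3700 nM. Compound 2, `Cc1cc(Nc2nn(Cc3cc(F)ccc3F)c(=O)c3ccccc23)n[nH]1`, carries a 2,5-difluorobenzyl, and compound 2 gives 3800 nM. Compound 3, `COc1ccc(Cn2nc(Nc3cc(C)[nH]n3)c3ccccc3c2=O)cc1`, carries a 4-methoxybenzyl, and compound 3 gives 4200 nM. The three numbers sit close together: the change from compound 1 to compound 2 is a 1.0-fold higher number from compound 1 to compound 2 (0.01 log units; within the scatter), from compound 1 to compound 3 it is a 1.1-fold higher number from compound 1 to compound 3 (0.06 log units; within the scatter), and from compound 2 to compound 3 it is a 1.1-fold higher number from compound 2 to compound 3 (0.04 log units; within the scatter). Compound 3 thus stands within the same band as the other two, and no ordering among them can be read from these numbers.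

Compound 4, `CC(=O)Nc1ccc(Cn2nc(Nc3cc(C)[nH]n3)c3ccccc3c2=O)cc1`, keeps the benzyl arm of compound 3 but changes its terminal group: acetamido in place of methoxy on an aromatic carbon. Going by the values given here, no measured pair tests this exact exchange. What the measured steps do show is that three rather different arms on the aromatic nitrogen leave the read-out essentially unchanged, so a modest edit at the far end of that arm is expected to do the same. The expected step is a 1.1-fold higher number from compound 3 to compound 4 (0.03 log units; within the scatter), within the scatter. Compound 4 is therefore estimated at 4500 nM, most likely between 1500 nM and 14000 nM.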

Compound 4, half-maximal inhibitory concentration: > 30000 nM
Compound 4: no number, only a limit (the forecaster's own chance of this, stated with the estimate: 10%); middle value at least 6.6-fold (0.82 log units) from the limit.
By their numbers in this assay, from the lowest: compounds 1, 2 and 3 (each within the scatter of the next). At a limit, above all of these: compound 4.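

The earlier compounds shown here made the arm on the aromatic nitrogen look forgiving, since a 4-methoxyphenyl, a 2,5-difluorobenzyl and a 4-methoxybenzyl all gave readings within the scatter of each other. The group at the far end of the benzyl arm, on an aromatic carbon para to a large group, turns out to matter far more: in this assay, acetamido in place of methoxy gives an at least 7.1-fold higher number from compound 3 to compound 4 (0.85 log units; beyond the scatter). The reading for compound 4 is a limit of the assay and not a number, so this step has a floor but no known size: the limit of > 30000 nM in this assay, at which 1 of the 4 values shown sits.

The acetamido group differs from methoxy in several ways at once, including its hydrogen-bond donor, its carbonyl and its greater number of heavy atoms, and this single exchange cannot separate them. Going by these compounds, it also remains open whether a smaller group at the same place, such as an amine or a hydroxyl, would stay close to compound 3, and whether acetamido would have the same effect on the 4-methoxyphenyl arm of compound 1, where no benzyl carbon is present.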